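The source may hold more compounds than are shown below. What is called first, only, known or untested is meant among the compounds shown, and "the series" means these compounds.

Compound 2 `Cc1ccc(Cn2cc(COc3ccc4c(=O)ccoc4c3)nn2)cc1` was examined in a functional assay on HeLa cells (Homo sapiens) for cytotoxicity, read by MTT assay, with a stated time of 48 h; a lower number here means a stronger inhibitor, a higher number a weaker inhibitor. In this assay compound 2 gives > 100000 nM, which is a limit of the assay rather than a number. Compound 1 `O=c1ccoc2cc(OCc3cn(Cc4ccccc4)nn3)ccc12` differs from compound 2 by a methyl in place of hydrogen on an aromatic carbon. In this assay compound 1 gives > 100000 nM, which is again a limit. The step that the two limits leave unreadable from compound 1 to compound 2 is therefore unreadable. Compound 3 `Cc1ccccc1Cn1cc(COc2ccc3c(=O)ccoc3c2)nn1` has not been measured; it differs from compound 2 by 2-methylphenyl in place of 4-methylphenyl on a saturated chain carbon bound to an aromatic nitrogen, the same atoms being joined differently. Among the measured compounds shown here, because both values shown sit at the limit of > 100000 nM in this assay, at which 2 of the 2 values shown sit, no measured step offers a readable size, and no direction can be taken from the data. Compound 3 is expected to give 100000 nM, with a range from 50000 nM to 300000 nM, most likely again reported only as a limit. The step of a number no higher from compound 2 to compound 3 (the limit leaves the size open) is thus expected to stay within the scatter.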

Compound 3, half-maximal inhibitory concentration: 15300 nM
Compound 3: middle estimate off by 6.5-fold (0.82 log units), on the high side, and the stated range ends above it.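

Exchanging 4-methylphenyl for 2-methylphenyl on the saturated chain carbon gives, in this assay, an at least 6.5-fold lower number from compound 2 to compound 3 (0.81 log units; beyond the scatter), so with the same atoms joined differently, where the methyl sits on the ring changes the result. Methyl in place of hydrogen on an aromatic carbon gives an at least 6.5-fold lower number from compound 1 to compound 3 (0.81 log units; beyond the scatter), the first readable sign that adding a methyl can matter here, though only in the form of 2-methylphenyl. Both sizes are minimum sizes, and the step between the other two compounds cannot be read, because their values are limits: the limit of > 100000 nM in this assay, at which 2 of the 3 values shown sit.

On these data alone, it remains open how 3-methylphenyl would compare, and whether a chlorine or methoxy group in place of the methyl of 2-methylphenyl would give a lower number. As far as these compounds go, whether a longer chain between the ring and the aromatic nitrogen would keep this gain is also open.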